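A few compounds are considered here, and "the series" means these few. Any claim that something is new, unique, unknown or untested is made for them only; others in the source may bear on it.

The measured compounds are compound 1, `Cc1ccc(OC[C@H](C)COc2ccc(C(=O)CC(C)(C)C)c(O)c2C)cc1C(=O)O`; compound 2, `COc1cc(C(=O)O)ccc1OC[C@H](C)COc1ccc(C(=O)CC(C)(C)C)c(O)c1C`; and compound 3, `Cc1cc(C(=O)O)ccc1OC[C@H](C)COc1ccc(C(=O)CC(C)(C)C)c(O)c1C`. In an assay for positive allosteric modulation of metabotropic glutamate receptor 3 (Rattus norvegicus) (a higher number here means that more compound is needed for the effect, a lower number that less compound is needed), compound 1 gives only a limit, > 10000 nM. Compound 2 gives 512 nM, and compound 3 gives 1520 nM, the highest of the two numbers obtained; the step of a 3.0-fold higher number from compound 2 to compound 3 (0.47 log units; beyond the scatter) separates them, and the step of an at least 6.5-fold lower number from compound 1 to compound 3 (0.81 log units; beyond the scatter) shows (the limit of > 10000 nM in this assay, at which 1 of the 3 values shown sits).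

Compound 4, `Cc1c(OC[C@@H](C)COc2ccc(C(=O)O)cc2F)ccc(C(=O)CC(C)(C)C)c1O`, is not yet measured. It differs from compound 3 by fluoro in place of methyl on an aromatic carbon. For the measured compounds named here, only the step from compound 2 to compound 3 concerns a change at this same aromatic carbon, and it was modest. For compound 4 a step of similar modest size in either direction is therefore expected, a 1.3-fold lower number from compound 3 to compound 4 (0.10 log units; within the scatter), and the number in this assay is estimated at 1200 nM, within 400 nM to 4000 nM.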

Compound 4, half-maximal effective concentration: 1300 nM
Beside the measured number, compound 4's estimate is 1.1-fold (0.03 log units) below it, and the stated range covers the measured number.
By their numbers in this assay, from the lowest: compound 2; then compounds 4 and 3 (each within the scatter of the next). At a limit, above all of these: compound 1.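

At this aromatic carbon, meta to a carboxy group, fluoro and methyl cannot be told apart in this assay (a 1.2-fold lower number from compound 3 to compound 4 (0.07 log units; within the scatter)). Methoxy stays apart from fluoro, as it did from methyl (a 2.5-fold higher number from compound 2 to compound 4 (0.40 log units; beyond the scatter)). The 4-carboxy-2-fluorophenyl group also stands well clear of the 3-carboxy-4-methylphenyl group of compound 1 (an at least 7.6-fold lower number from compound 1 to compound 4 (0.88 log units; beyond the scatter)), but this step rests on a limit: the limit of > 10000 nM in this assay, at which 1 of the 4 values shown sits.

The compounds shown leave open whether ethoxy or hydroxy at this carbon would match methoxy. They also leave open whether chloro or plain hydrogen would match fluoro and methyl.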